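This account rests on a few compounds, and the source may have more. Where it says the series, first, only, none or still open, it means among the compounds named here.

The measured compounds:

Compound 1, `Nc1ccccc1/C=C/c1cccc(O)c1`, gives 30 ug/mL in a functional assay on HT-29 cells (Homo sapiens) for inhibition, read by MTT assay, with a stated time of 2 days; a lower number here means a stronger inhibitor, a higher number a weaker inhibitor.
Compound 3, `COc1ccccc1/C=C/c1cccc(O)c1`, gives 17 ug/mL in this assay.
Compound 2, `Nc1ccccc1/C=C/c1ccc(O)cc1`, gives only a limit of the assay, > 100 ug/mL.

Compound 1 and compound 3 share a core and differ in one place: methoxy in place of amino on an aromatic carbon. That change made a 1.8-fold lower number from compound 1 to compound 3 (0.25 log units; within the scatter). Compound 2 is built from the same atoms as compound 1, joined differently; how the two cores differ is not broken down here. Compound 2 sits at a limit of the assay, as the limit of > 100 ug/mL in this assay, at which 1 of the 3 values shown sits, shows, so it is known only as a weak inhibitor and not as a number.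

Compound 4, `COc1ccccc1/C=C/c1ccc(O)cc1`, has not yet been measured. Among the compounds with values here, it differs from compound 2 by the same change as the one from compound 1 to compound 3: methoxy in place of amino on an aromatic carbon.

The step from compound 2 to compound 4 is expected to be a number no higher from compound 2 to compound 4 (the limit leaves the size open), beside the measured 1.8-fold lower number from compound 1 to compound 3 (0.25 log units; within the scatter), because that measured step stayed within the scatter. Since compound 2 itself gave only a limit, compound 4 may also come back as a limit rather than a number. Compound 4 is expected to give about 100 ug/mL, with a likely range from 40 ug/mL to 250 ug/mL.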

Compound 4, half-maximal inhibitory concentration: 24 ug/mL
Compound 4: the middle estimate sits 4.2-fold (0.62 log units) above what was measured; the whole stated range lies above it.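

Replacing amino with methoxy on an aromatic carbon gave an at least 4.1-fold lower number from compound 2 to compound 4 (0.61 log units; beyond the scatter) in this assay, whereas on the core of compound 1 the same change stayed within the scatter of repeated measurements. In this assay, compound 2 gives > 100 ug/mL, which is a limit of the assay and not a number. The change therefore carried over to the second core without raising the number, and compound 4 gave a measurable value, but this does not show whether the size of the step is the same or different on the two cores: the same change on two cores in this assay, a 1.8-fold lower number (0.25 log units; within the scatter) from compound 1 to compound 3 and an at least 4.1-fold lower number (0.61 log units; beyond the scatter) from compound 2 to compound 4; the limit leaves it open whether they differ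

The compounds shown leave open what other groups in the same place would do, such as an ethoxy group, a longer chain or a carboxylic acid. With only two cores shown, they also leave open whether this change would behave the same way on any further core.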